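Anilino variants of the quinone core in HeLa growth inhibition

The compounds below may be only part of what the source reports. "The series", "measured", "known", "first", "only" and "open" are said of these compounds alone.

Compound 1, `O=C1C=C(NCc2ccccc2)C(=O)c2c1nc1n2[C@H]2OC[C@@H](O)[C@H]2OC1`, carries a benzylamino group on the shared core. In a functional assay on HeLa cells (Homo sapiens) for inhibition, read by sulforhodamine B assay (a higher number here means a weaker inhibitor, a lower number a stronger inhibitor), compound 1 gives only a limit, > 8000 nM, and no number. Compound 2, `O=C1C(NC2CCCCC2)=CC(=O)c2c1nc1n2[C@H]2OC[C@@H](O)[C@H]2OC1`, likewise reaches only a limit in this assay, > 16000 nM. Compound 3, `O=C1C(Nc2ccccc2F)=CC(=O)c2c1nc1n2[C@H]2OC[C@@H](O)[C@H]2OC1`, gives 9820 nM in this assay. Among the measured compounds shown here, the one measured step, an at least 1.6-fold lower number from compound 2 to compound 3 (0.21 log units; that floor lies within the scatter), exchanges a saturated ring for a fluorinated aromatic ring on the amine nitrogen and stays within the scatter. Compound 4, `O=C1C=C(Nc2cccc(F)c2)C(=O)c2c1nc1n2[C@H]2OC[C@@H](O)[C@H]2OC1`, differs from compound 1 by 3-fluorophenyl in place of benzyl on an amine nitrogen. Because that change resembles the step of an at least 1.6-fold lower number from compound 2 to compound 3 (0.21 log units; that floor lies within the scatter), no shift beyond the scatter is expected in this assay, and the step that the limit leaves unreadable from compound 1 to compound 4 is the estimate. Compound 4 is therefore expected to give about 9000 nM in this assay, between 4000 nM and 20000 nM.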

Compound 4, half-maximal inhibitory concentration: 6440 nM
The estimate for compound 4 lay 1.4-fold (0.15 log units) above the measured number; the measured number falls inside the stated range.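

Compound 1 stands only at a limit in this assay: the limit of > 8000 nM in this assay, at which 1 of the 4 values shown sits.

The exchange of benzyl for 3-fluorophenyl on the amine nitrogen gives an at least 1.2-fold lower number from compound 1 to compound 4 (0.09 log units; that floor lies within the scatter). Compound 4 thus supplies a number at this place on the shared core, but the step shows no gain that can be told from the scatter.

Open, on these data alone, is what plain phenyl, or a ring carrying a methoxy group or a carboxylic acid in place of fluorine, would give at this place in this assay. As far as these compounds go, the full size of the step also remains open, with compound 1 known only as a limit.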